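The source may report more compounds than this note shows. Statements on the series, on what has been measured and on what is new or still open speak of the compounds shown alone.

Compound 1 `C=CC1=C(C(=O)NCc2ccc(Cl)cc2)C(c2ccc(F)cc2)OC1` carries a 4-chlorobenzyl group on the amide-type nitrogen and a 4-fluorophenyl group on the shared core. In a functional assay on SW480 cells (Homo sapiens) for cytotoxicity, read by MTT assay, with a stated time of 24 h (on this read-out lower numbers stand for stronger inhibition and higher numbers for weaker inhibition), compound 1 gives only a limit of > 100000 nM, not a number. Compound 2 `C=CC1=C(C(=O)Nc2ccccc2OC)C(c2ccc(F)cc2)OC1` and compound 3 `C=CC1=C(C(=O)NCc2ccccc2F)C(c2ccc(F)cc2)OC1` vary the substituent on the amide-type nitrogen. In this assay compound 2 likewise gives only a limit, > 100000 nM. In this assay compound 3 also returns only a limit, > 100000 nM. Because all three values sit at the limit of > 100000 nM in this assay, at which 3 of the 3 values shown sit, the steps a step that the two limits leave unreadable from compound 1 to compound 2, a step that the two limits leave unreadable from compound 1 to compound 3 and a step that the two limits leave unreadable from compound 2 to compound 3 cannot be read in either size or direction.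

Compound 4 `C=CC1=C(C(=O)NCc2ccc(Cl)cc2)C(c2ccc(OC)cc2)OC1` differs from compound 1 in one place: methoxy in place of fluoro on an aromatic carbon. Going by the values given here, none of the measured steps touches this position, and none of them yields a readable size, so they offer no direction for the change to compound 4. What they do show is that three variations on the amide side all left compound 1, compound 2 and compound 3 at the limit. The expected step is a number no higher from compound 1 to compound 4 (the limit leaves the size open), with no movement beyond the scatter that the data could support. Compound 4 is therefore estimated at about 100000 nM, within a range from 30000 nM to 300000 nM, and will most likely be reported only as a limit again.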

Compound 4, half-maximal inhibitory concentration: > 100000 nM
Compound 4 gave a limit, no number; the forecaster's own chance of this, stated with the estimate: 85%; the middle value sits exactly at the limit.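

In this assay compound 4 gives only a limit, > 100000 nM, not a number. No new step can be read between compound 1 and compound 4, because neither has a number to compare: the limit of > 100000 nM in this assay, at which 4 of the 4 values shown sit. The compounds shown leave open whether any change to compound 1 would give a measurable value in this assay.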